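The compounds below may be only part of what the source reports. "The series", "measured", "known", "first", "only" and "open" are said of these compounds alone.

Compound 1 `Cc1nc2c(/C=C\Cc3ccccc3)cccn2c1C` and compound 2 `Cc1nc2c(C/C=C\c3ccccc3)cccn2c1C` share the same atoms joined differently; the difference between the two cores is not broken down here. In a functional assay on the whole organism for inhibition, with Rattus norvegicus as the target, with a stated time of 1 h (a higher number here means that more compound is needed for the effect, a lower number that less compound is needed), compound 1 gives 6.6 mg/kg, and compound 2 gives 5.5 mg/kg. Compound 3 `Cc1nc2c(/C=C\Cc3ccccc3)cccn2c1N` carries the change amino in place of methyl on an aromatic carbon on the core of compound 1, and in this assay compound 3 gives 8.6 mg/kg, a step of a 1.3-fold higher number from compound 1 to compound 3 (0.11 log units; within the scatter). Compound 4 `Cc1nc2c(C/C=C\c3ccccc3)cccn2c1N` carries the same change, (amino in place of methyl on an aromatic carbon), on the core of compound 2. Because the step of a 1.3-fold higher number from compound 1 to compound 3 (0.11 log units; within the scatter) was small, a step of about a 1.3-fold higher number from compound 2 to compound 4 (0.10 log units; within the scatter) is expected from compound 2 to compound 4, resting on that single earlier example. For compound 4 the expected value in this assay is 7 mg/kg, estimated to fall between 4 mg/kg and 12 mg/kg.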

Compound 4, dose for half-maximal effect: 6.4 mg/kg
The estimate for compound 4 lay 1.1-fold (0.04 log units) above the measured number; measured number inside the range.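

Amino in place of methyl on an aromatic carbon gives, in this assay, a 1.2-fold higher number from compound 2 to compound 4 (0.07 log units; within the scatter). Set beside the earlier step, the change reads the same on both cores: the same change on two cores in this assay, a 1.3-fold higher number (0.11 log units; within the scatter) from compound 1 to compound 3 and a 1.2-fold higher number (0.07 log units; within the scatter) from compound 2 to compound 4, 1.1-fold (0.05 log units) apart, within the scatter of two such steps

So in this assay the swap carries from one core to the other, and on both cores the dose stays within the usual scatter. This does not show that amino is better or worse than methyl, and two cores make no rule for a wider series.

On these data alone, only methyl and amino appear at this place, so a carboxylic acid, a dimethylamino group or a longer chain there remains open. Also open, as far as these compounds go, is whether any group at this place would shift the dose beyond the scatter.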